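A few compounds are considered here, and "the series" means these few. Any claim that something is new, unique, unknown or untested is made for them only; others in the source may bear on it.

Series notes, metabotropic glutamate receptor 5 binding.

Measured so far in an assay on isolated protein for displacement of a labelled ligand from metabotropic glutamate receptor 5 (Homo sapiens), with a stated time of 60 min, tested at 1 uM; on this read-out lower numbers stand for less inhibition and higher numbers for more inhibition at the one concentration tested (going by the name of the read-out):
compound 1 `CC1CCN(c2c(S(=O)(=O)c3ccccc3)cnc3cc(Cl)ccc23)CC1` gives 93%
compound 2 `COc1ccc(S(=O)(=O)c2cnc3cc(Cl)ccc3c2N2CCC(C)CC2)cc1` gives 79%
compound 3 `COc1cccc(S(=O)(=O)c2cnc3cc(F)ccc3c2N2CCC(C)CC2)c1` gives 90%

Compound 3 is the second highest of the three readings; its gap to compound 1 lies within the scatter, its gap to compound 2 beyond it. Among the compounds with values here, the only step between measured compounds that differ in one place is a number 14 percentage points lower from compound 1 to compound 2 (beyond the scatter), which concerns a methoxy in place of hydrogen on an aromatic carbon and so does not touch a halogen. Compound 2 and compound 3 differ in two places at once, so their values show only that both a chloro and a fluoro variant give a high reading.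

Compound 4 `COc1cccc(S(=O)(=O)c2cnc3cc(Cl)ccc3c2N2CCC(C)CC2)c1` is next for this assay. The change from compound 3 is chloro in place of fluoro on an aromatic carbon. Within the data shown here, no measured step in this set bears directly on a chloro in place of fluoro; the expectation is therefore a step of a number 2 percentage points lower from compound 3 to compound 4 (within the scatter), within the scatter, in no firm direction. Compound 4 is estimated at 88%, with a range of 76% to 97%.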

Compound 4, a percentage reported as inhibition, at one concentration (the size of the read-out at that concentration, not a potency): 93%
Compound 4: middle estimate off by 5 percentage points, on the low side, within the range that was stated.
By their numbers in this assay, from the lowest: compound 2; then compounds 3, 1 and 4 (each within the scatter of the next).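

In this assay the chloro in place of fluoro on this aromatic carbon gives a number 3 percentage points higher from compound 3 to compound 4 (within the scatter) and so shows no separation between the two halogens, at least with the 3-methoxyphenyl on the sulfonyl sulfur. On that sulfur the placing of the methoxy now counts: 3-methoxyphenyl in place of 4-methoxyphenyl gives a number 14 percentage points higher from compound 2 to compound 4 (beyond the scatter) and methoxy in place of hydrogen gives no change at the digits printed from compound 1 to compound 4 (within the scatter), so the drop of a number 14 percentage points lower from compound 1 to compound 2 (beyond the scatter) goes with the 4-methoxyphenyl group of compound 2 and not with a methoxy as such. No supporting data are available to explain any of these steps.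

As far as these compounds go, whether a bromo, a nitrile or plain hydrogen on this carbon would read the same stays open. Also open is how a carboxylic acid or an amine on the phenyl of the sulfonyl group would read, and the percentages at one concentration give no potency for any of these compounds.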